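The compounds below may be only part of what the source reports. "The series", "measured", "known", "first", "only" and "open" are said of these compounds alone.

Three related compounds have been tested in a functional assay on LNCaP cells (Homo sapiens) for antiproliferative activity, read by propidium iodide staining, with a stated time of 96 h; on this read-out lower numbers stand for stronger inhibition and higher numbers for weaker inhibition. In this assay, compound 1 (`CC(O)(COc1cccc(C(F)(F)F)c1)C(=O)Nc1ccc(S(F)(F)(F)(F)F)cc1`) gives 24700 nM, compound 2 (`CC(O)(COc1cccc(S(F)(F)(F)(F)F)c1)C(=O)Nc1ccc(C(F)(F)F)cc1`) gives 12800 nM and compound 3 (`CC(O)(CS(=O)(=O)c1cccc(C(F)(F)F)c1)C(=O)Nc1cccc(S(F)(F)(F)(F)F)c1`) gives 21800 nM. All three numbers lie within the usual scatter of repeated measurements, so compound 3 cannot be told apart from either of the others.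

Compound 4 (`CC(O)(CS(=O)(=O)c1cccc(OC(F)(F)F)c1)C(=O)Nc1cccc(S(F)(F)(F)(F)F)c1`) has not yet been measured. It differs from compound 3 in one place, with trifluoromethoxy in place of trifluoromethyl on an aromatic carbon, meta to a large group: trifluoromethoxy in place of trifluoromethyl on an aromatic carbon.

Within the data shown here, no two tested compounds differ in only one place, so the data offer no direct measure of this swap. The best guide is compound 3 at 21800 nM, and no shift beyond the scatter is expected in this assay. The expected step, a 1.1-fold lower number from compound 3 to compound 4 (0.04 log units; within the scatter), is an estimate that stays within that scatter. For compound 4 the estimated value is 20000 nM, with an expected range from 9000 nM to 45000 nM.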

Compound 4, half-maximal inhibitory concentration: 15100 nM
The estimate for compound 4 lay 1.3-fold (0.12 log units) above the measured number; low and high end bracket the measured number.
By their numbers in this assay, from the lowest: compounds 2, 4, 3 and 1 (each within the scatter of the next).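

Among these compounds, compound 3 and compound 4 form the first pair here that differs in one place only, so they give the first direct reading of a change on this aromatic ring. In this assay putting trifluoromethoxy in place of trifluoromethyl gives a 1.4-fold lower number from compound 3 to compound 4 (0.16 log units; within the scatter) and so the two compounds cannot be told apart. At this position the added oxygen therefore leaves no measurable mark on the read-out, and no available evidence bears on why.

The compounds shown leave open whether a different kind of group on this carbon, such as an amine or a carboxylic acid, would move the number beyond the scatter. They also leave open whether the same swap would read alike on the core of compound 1.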